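The compounds below may be only part of what the source reports. "The series", "measured", "known", "first", "only" and "open" are said of these compounds alone.

Measured compounds:
compound 1 `O=C(COc1c(-c2ccccc2)oc2ccccc2c1=O)Nc1ccc2ccccc2c1`: 6520 nM
compound 2 `O=C(COc1ccc2oc(-c3ccccc3)cc(=O)c2c1)Nc1ccc2ccccc2c1`: 6750 nM

Both numbers come from a functional assay on NPC-TW01 cells (Homo sapiens) for antiproliferative activity, read by MTT assay, with a stated time of 72 h; a lower number here means a stronger inhibitor of growth, a higher number a weaker inhibitor of growth. Compound 1 has the lower of the two numbers, but compound 2 sits within the scatter of it, so the two cannot be ordered on this assay; the two compounds differ in their cores, and no difference between them is computed here. Compound 3 `O=C(COc1c(-c2ccccc2)oc2ccccc2c1=O)Nc1ccccc1` is the next compound, so far unmeasured in this assay. It keeps the core of compound 1 and changes only the group on the amide nitrogen: phenyl in place of naphthalen-2-yl on an amide-type nitrogen. For the measured compounds named here, no pair of measured compounds shows a step of this kind, so the size of the change rests on expectation alone. Exchanging the larger naphthalen-2-yl group for phenyl is expected to give a somewhat weaker inhibitor in this assay, a step in the direction of a higher number, though an outcome within the scatter of compound 1 cannot be ruled out. The expected step from compound 1 to compound 3 is a 1.5-fold higher number from compound 1 to compound 3 (0.19 log units; within the scatter). Compound 3 is estimated at 10000 nM in this assay, with a range from 3500 nM to 30000 nM.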

Compound 3, concentration for 50% growth inhibition: > 10000 nM
Compound 3 was reported as a limit; the forecaster's own chance of this, stated with the estimate: 15%; the middle value sits exactly at the limit.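

In this assay, compound 3 is reported as a limit and not as a number: the limit of > 10000 nM in this assay, at which 1 of the 3 values shown sits.

Phenyl in place of naphthalen-2-yl on an amide-type nitrogen gives an at least 1.5-fold higher number from compound 1 to compound 3 (0.18 log units; that floor lies within the scatter). For the compounds shown here, this is the first step that can be read with the core held fixed, since the two earlier compounds differ in their cores, and it places the group on the amide nitrogen under direct comparison for the first time. Going by these compounds, its floor lies within the scatter, so the result does not establish that compound 3 is a weaker inhibitor of growth than compound 1, and the true size of the step remains unknown, with no upper bound.

The compounds shown leave open how groups other than these two would read on the same nitrogen, for example benzyl, naphthalen-1-yl, or a phenyl ring carrying a methoxy group or a chlorine atom. They also leave open whether the same exchange of naphthalen-2-yl for phenyl on the core of compound 2 would give a step of similar direction.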